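The compounds below may be only part of what the source reports. "The series", "measured", "known", "first", "only" and "open" are said of these compounds alone.

Series notes. Compound 2 `CCOc1cc(NC(=O)C2(NC(=O)c3ccc4c(C5CCCC5)c(-c5ncc(Cl)cn5)n(C)c4c3)CCC2)ccc1/C=C/C(=O)OCOP(=O)(O)O` stands highest in an ADME assay on stomach for pharmacokinetics, in simulated gastric fluid (on this read-out lower numbers stand for a shorter-lived compound and higher numbers for a longer-lived compound), among the three measured compounds, at 1.3 h. Compound 3 `CCOc1cc(NC(=O)C2(NC(=O)c3ccc4c(C5CCCC5)c(-c5ncc(Cl)cn5)n(C)c4c3)CCC2)ccc1/C=C/C(=O)OCC(N)=O` gives 0.6 h in this assay, and compound 1 `CCOc1cc(NC(=O)C2(NC(=O)c3ccc4c(C5CCCC5)c(-c5ncc(Cl)cn5)n(C)c4c3)CCC2)ccc1/C=C/C(=O)N[C@@H](CCC(=O)O)C(N)=O` gives 0.533 h; the two gaps are a 2.2-fold lower number from compound 2 to compound 3 (0.34 log units; beyond the scatter) and a 2.4-fold higher number from compound 1 to compound 2 (0.39 log units; beyond the scatter). Compound 4 `CCOc1cc(NC(=O)C2(NC(=O)c3ccc4c(C5CCCC5)c(-c5ncc(Cl)cn5)n(C)c4c3)CCC2)ccc1/C=C/C(=O)OCC(=O)N1CCOCC1` is compound 2 with a group of 8 heavy atoms (5 carbon, 1 nitrogen, 2 oxygen; one six-membered non-aromatic ring with 2 hetero atoms) in place of a group of 5 heavy atoms (4 oxygen, 1 phosphorus; no ring), on a saturated chain carbon bound to an oxygen next to a carbonyl group. Among the measured compounds shown here, the step that bears most on it is a 2.2-fold lower number from compound 2 to compound 3 (0.34 log units; beyond the scatter), the only measured change at the same place, which exchanged the phosphorus-bearing group for a carbamoylmethyl chain; compound 4 carries a morpholinyl carbonyl group there instead. For compound 4 a drop of similar size is therefore expected: a 2.2-fold lower number from compound 2 to compound 4 (0.34 log units; beyond the scatter). Compound 4 is estimated at 0.6 h, with a range of 0.3 h to 1.2 h.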

Compound 4, half-life: 0.85 h
Compound 4: the middle estimate sits 1.4-fold (0.15 log units) below what was measured, within the range that was stated.
By their numbers in this assay, from the lowest: compounds 1, 3, 4 and 2 (each within the scatter of the next, the first and the last beyond it).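

In this assay, the (morpholin-4-yl)carbonyl group on this saturated chain carbon stays within the scatter of the group it replaces (a 1.5-fold lower number from compound 2 to compound 4 (0.18 log units; within the scatter)), whereas the change to compound 3 goes beyond it (a 2.2-fold lower number from compound 2 to compound 3 (0.34 log units; beyond the scatter)). Morpholin-4-yl in place of amino on a carbonyl carbon (a 1.4-fold higher number from compound 3 to compound 4 (0.15 log units; within the scatter)) and the exchange against compound 1 (a 1.6-fold higher number from compound 1 to compound 4 (0.20 log units; within the scatter)) also stay within the scatter, so compound 4 separates from none of the other three. No evidence is available on what underlies these readings.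

From the compounds shown here alone, whether a piperidin-1-yl or dimethylamino group in place of morpholin-4-yl would read alike in this assay remains open.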